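The compounds below may be only part of what the source reports. "The series", "measured", "known", "first", "only" and "open" are said of these compounds alone.

Measured so far:
compound 1, `O=C(CN(c1ncnc2c1ncn2C1CCCCO1)C1CC1)N[C@@H](CC(=O)OCc1ccccc1)C(=O)OCc1ccccc1` — 25.1%
compound 2, `N=C(N)NCCC[C@H](NC(=O)CN(c1ncnc2c1ncn2C1CCCCO1)C1CC1)C(=O)OCc1ccccc1` — 61.6%

For the measured compounds named here, compound 2 holds the higher of the two numbers so far in a functional assay on the whole organism (Tail, strain ICR) with Mus musculus as the target, in the tail flick test, with a stated time of 90 min, at a dose of 25 umol/kg by the oral route (a lower number here means a weaker effect, a higher number a stronger effect of the compound at the dose given), with compound 1 the nearest, a number 36.5 percentage points higher from compound 1 to compound 2 (beyond the scatter).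

Compound 3, `CC(C)C[C@H](NC(=O)CN(c1ncnc2c1ncn2C1CCCCO1)C1CC1)C(=O)OCc1ccccc1`, is not yet measured. It differs from compound 2 by a group of 3 heavy atoms (3 carbon; no ring) in place of a group of 6 heavy atoms (3 carbon, 3 nitrogen; no ring), on a saturated chain carbon, two bonds along the chain from an amide-type nitrogen and a carbonyl carbon. Going by the values given here, the group that leaves is the same group of 6 heavy atoms (3 carbon, 3 nitrogen; no ring) that entered in the single measured step, where its arrival in place of a group of 10 heavy atoms gave a number 36.5 percentage points higher from compound 1 to compound 2 (beyond the scatter). That step is the only one that bears on the present change, and it points to the group of 6 heavy atoms as carrying much of the activity of compound 2. Among the compounds with values here, compound 3 keeps neither the 10-heavy-atom group of compound 1 nor the 6-heavy-atom group of compound 2, so there is no measured pair that matches the isopropyl directly. A downward step is expected, a number 29.6 percentage points lower from compound 2 to compound 3 (beyond the scatter), of a size comparable to the measured step but uncertain.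

Compound 3 is estimated at 32%, within 12% to 58%.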

Compound 3, a percentage reported as activity, at one dose (the size of the read-out at that dose, not a potency): 28.2%
Beside the measured number, compound 3's estimate is 3.8 percentage points above it; the measured number falls inside the stated range.
By their numbers in this assay, from the lowest: compounds 1 and 3 (each within the scatter of the next); then compound 2.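

In this assay, isopropyl in place of the group of 6 heavy atoms gives a number 33.4 percentage points lower from compound 2 to compound 3 (beyond the scatter) and so removes most of what the earlier step had gained at this position, on a saturated chain carbon, two bonds along the chain from an amide-type nitrogen and a carbonyl carbon. Isopropyl and benzyloxycarbonyl differ in size and in content, with no ring and no oxygen in the first, yet the change between them gives a number 3.1 percentage points higher from compound 1 to compound 3 (within the scatter) and leaves the two groups without a readable difference, so that among these three compounds only the nitrogen-bearing group of compound 2 stands apart, and no compound shown goes against this. Nothing available on these compounds gives a reason for that separation.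

On these data alone, whether the reading of compound 2 needs the whole group of 6 heavy atoms or only a nitrogen at the end of a chain remains open, and a chain ending in a primary amine or a urea at the same position would address it. As far as these compounds go, the effect of a free carboxylic acid in place of the benzyl ester, with each of these groups retained, also remains open.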